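The source may hold more compounds than are shown below. What is called first, only, known or untested is meant among the compounds shown, and "the series" means these compounds.

Compound 2 `COc1ccc(-c2nn(-c3ccccc3)cc2C(=O)NOCc2ccccc2)cc1` gives the higher of the two numbers measured in an ADME assay on HEK-293T cells (Homo sapiens) for antiproliferative activity, read by MTT assay, with a stated time of 48 h, in the presence of a further agent that is not named here (on this read-out lower numbers stand for higher toxicity in this test and higher numbers for lower toxicity in this test), at 201000 nM. Compound 1 `Cc1ccc(-c2nn(-c3ccccc3)cc2C(=O)NOCc2ccccc2Cl)cc1`, which differs from it in two places, gives 38700 nM in this assay. Compound 3 `COc1ccc(-c2nn(-c3ccccc3)cc2C(=O)NOCc2ccccc2Cl)cc1` arises from compound 2 by a single change: chloro in place of hydrogen on an aromatic carbon. For the measured compounds named here, no measured pair shows this change on its own. The step from compound 2 to compound 3 is expected to be a 2.0-fold lower number from compound 2 to compound 3 (0.30 log units; within the scatter), a modest move toward a lower number, about the size of the usual scatter. For compound 3 the estimated value in this assay is 100000 nM, between 40000 nM and 250000 nM.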

Compound 3, half-maximal cytotoxic concentration: 586000 nM
For compound 3 the middle estimate is 5.9-fold (0.77 log units) below the measured one; measured number outside the range, above it.
By their numbers in this assay, from the lowest: compound 1; then compound 2; then compound 3.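

In this assay, changing benzyl to 2-chlorobenzyl gives a 2.9-fold higher number from compound 2 to compound 3 (0.46 log units; beyond the scatter), so here this chloro moves the compound toward lower toxicity in this test. With the 2-chlorobenzyl group kept, methoxy in place of methyl on an aromatic carbon gives a 15-fold higher number from compound 1 to compound 3 (1.18 log units; beyond the scatter), a large step. Nothing available explains either step. From the compounds shown here alone, whether chloro has the same effect alongside methyl remains open. So does the effect of an amine or a carboxylic acid in place of the chloro.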